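Weak Growth Inhibitors: From Compound 3 to Compound 4

The compounds below may be only part of what the source reports. "The series", "measured", "known", "first", "only" and "open" are said of these compounds alone.

compound 1 `COc1ccc(Nc2ncc(C(F)(F)F)c(N3Cc4cccc(N(C)S(C)(=O)=O)c4C3)n2)cc1C(F)(F)F`: > 30000 nM
compound 2 `CN(c1cccc2c1CN(c1nc(Nc3cc(C(F)(F)F)cc(C(F)(F)F)c3)ncc1C(F)(F)F)C2)S(C)(=O)=O`: > 30000 nM
compound 3 `Cc1cc(Cl)ccc1Nc1ncc(C(F)(F)F)c(N2Cc3cccc(N(C)S(C)(=O)=O)c3C2)n1`: 25500 nM

In a functional assay on A549 cells (Homo sapiens) for antiproliferative activity, read by spectrophotometry, with a stated time of 2 days (a lower number here means a stronger inhibitor of growth, a higher number a weaker inhibitor of growth), compound 1 gives > 30000 nM, which is a limit of the assay, not a number. Compound 2 likewise gives > 30000 nM, again a limit. Within the data shown here, compound 3 gives 25500 nM, the only number in the set. The other two values, those of compound 1 and compound 2, are limits (the limit of > 30000 nM in this assay, at which 2 of the 3 values shown sit). Among the measured compounds shown here, the single measured step, an at least 1.1-fold lower number from compound 1 to compound 3 (0.07 log units; that floor lies within the scatter), lies within the scatter. Compound 4 `COc1ccc(C(F)(F)F)cc1Nc1ncc(C(F)(F)F)c(N2Cc3cccc(N(C)S(C)(=O)=O)c3C2)n1` differs from compound 3 by 2-methoxy-5-(trifluoromethyl)phenyl in place of 4-chloro-2-methylphenyl on a nitrogen on an aromatic ring, bringing in the same methoxy and trifluoromethyl groups carried by compound 1 in its own arrangement. Because compound 1 sits at the limit of > 30000 nM in this assay, at which 2 of the 3 values shown sit, compound 4 is expected to come out at or near that limit, with the step of a 1.4-fold higher number from compound 3 to compound 4 (0.14 log units; within the scatter). Compound 4 is estimated at 35000 nM, in the range 15000 nM to 100000 nM.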

Compound 4, concentration for 50% growth inhibition: > 30000 nM
Compound 4 ended at the assay's limit (the forecaster's own chance of this, stated with the estimate: 60%); the middle value does not contradict the limit.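

Setting 2-methoxy-5-(trifluoromethyl)phenyl in place of 4-chloro-2-methylphenyl on a nitrogen on an aromatic ring gives an at least 1.1-fold higher number from compound 3 to compound 4 (0.07 log units; that floor lies within the scatter). The value of compound 4 is a limit, so this second arrangement of methoxy and trifluoromethyl gives no number in this assay, and the step between compound 1 and compound 4 cannot be read. The set now gathers at one ceiling: the limit of > 30000 nM in this assay, at which 3 of the 4 values shown sit.

As far as these compounds go, whether any group at this position gives clearly stronger growth inhibition remains open, since compound 3 alone has a number. Also open, from the compounds shown here alone, is what an amine or a carboxylic acid on this phenyl ring would give.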